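A few compounds are considered here, and "the series" means these few. Any claim that something is new, unique, unknown or untested is made for them only; others in the source may bear on it.

Compounds with results in an ADME assay on Vero cells (Chlorocebus sabaeus) for cytotoxicity, read by MTT assay, with a stated time of 72 h; on this read-out higher numbers stand for lower toxicity in this test and lower numbers for higher toxicity in this test:

compound 1, `COC(=O)c1cc(-c2cccc(NC(=O)c3ccc(/C=C/C(=O)c4cccnc4)cc3)c2)on1` — "not determined" (no result reported)
compound 2, `COC(=O)c1cc(-c2cccc(NC(=O)c3ccc(/C=C/C(=O)c4cccc([N+](=O)[O-])c4)cc3)c2)on1` — > 40 ug/mL
compound 3, `COC(=O)c1cc(-c2cccc(NC(=O)c3ccc(/C=C/C(=O)c4ccc(OC)cc4)cc3)c2)on1` — > 10 ug/mL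

Compound 2 gives only a limit of this assay, > 40 ug/mL; it stands at the limit of > 40 ug/mL in this assay, at which 1 of the 3 values shown sits. Compound 3 likewise gives only a limit, > 10 ug/mL, which is the limit of > 10 ug/mL in this assay, at which 1 of the 3 values shown sits. For compound 1 no result in this assay was reported. Among the compounds with values here, the one step between measured compounds, a step that the two limits leave unreadable from compound 2 to compound 3, is therefore unreadable: two limits do not make a number that can be compared.

Compound 4, `COC(=O)c1cc(-c2cccc(NC(=O)c3ccc(/C=C/C(=O)c4ccc(Cl)cc4Cl)cc3)c2)on1`, differs from compound 2 by 2,4-dichlorophenyl in place of 3-nitrophenyl on a carbonyl carbon. Within the data shown here, no measured step in this assay bears on this change with a readable size, so no direction can be taken from the series. The expected step of a number no higher from compound 2 to compound 4 (the limit leaves the size open) is set at none beyond the scatter. Compound 4 is estimated at 40 ug/mL, within a range from 15 ug/mL to 90 ug/mL, and the expectation is that this assay again reports only a limit rather than a number.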

Compound 4, half-maximal cytotoxic concentration: > 40 ug/mL
Compound 4: no number, only a limit; the forecaster's own chance of this, stated with the estimate: 70%; the middle value sits exactly at the limit.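

In this assay compound 4 gives > 40 ug/mL, which is a limit. Compound 2 and compound 3 also give only limits, so no step among these compounds can be read. The compounds shown leave open whether 3-nitrophenyl, 4-methoxyphenyl and 2,4-dichlorophenyl differ in cytotoxicity at all.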